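Removing the methylsulfonyl from the pyridine amine

This account rests on a few compounds, and the source may have more. Where it says the series, first, only, none or still open, it means among the compounds named here.

Compound 2 `CS(=O)(=O)Nc1ccc(-c2ccc(C(=O)N[C@H]3CN[C@@H](C(=O)Nc4ccc(Cl)c(C(F)(F)F)c4)C3)cc2)cn1` stands second highest of the three numbers in a functional assay on K562 cells (Homo sapiens) for inhibition, read by MTT assay, with a stated time of 48 h (on this read-out lower numbers stand for stronger inhibition and higher numbers for weaker inhibition), where compound 2 gives 45000 nM. Compound 1 `O=C(NC1CC1)c1cncc(-c2ccc(C(=O)N[C@H]3CN[C@@H](C(=O)Nc4ccc(Cl)c(C(F)(F)F)c4)C3)cc2)c1` gives 65300 nM and compound 3 `CCN(CC)C(=O)c1cncc(-c2cccc(C(=O)N[C@H]3CN[C@@H](C(=O)Nc4ccc(Cl)c(C(F)(F)F)c4)C3)c2)c1` gives 24900 nM; both sit within the scatter of compound 2. Compound 4 `Nc1ccc(-c2ccc(C(=O)N[C@H]3CN[C@@H](C(=O)Nc4ccc(Cl)c(C(F)(F)F)c4)C3)cc2)cn1` differs from compound 2 by hydrogen in place of methylsulfonyl on a nitrogen on an aromatic ring. Among the compounds with values here, the only measured step touching this part of the molecule is a 1.5-fold lower number from compound 1 to compound 2 (0.16 log units; within the scatter), which swapped the whole pyridinyl substituent without moving the number beyond the scatter. Nothing measured isolates the methylsulfonyl itself, so no step beyond the scatter is expected for no change at the digits printed from compound 2 to compound 4 (within the scatter). Compound 4 is therefore estimated at 45000 nM in this assay, with a range from 15000 nM to 135000 nM.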

Compound 4, half-maximal inhibitory concentration: 9130 nM
Compound 4: middle estimate off by 4.9-fold (0.69 log units), on the high side, outside the stated range (below it).
By their numbers in this assay, from the lowest: compound 4; then compounds 3, 2 and 1 (each within the scatter of the next, the first and the last beyond it).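

In this assay, within the data shown here, taking the methylsulfonyl off the nitrogen gives a 4.9-fold lower number from compound 2 to compound 4 (0.69 log units; beyond the scatter) and so shows a step beyond the scatter at this position, which the earlier compounds did not. Compared with the 5-(cyclopropylcarbamoyl)pyridin-3-yl substituent, 6-aminopyridin-3-yl gives a 7.2-fold lower number from compound 1 to compound 4 (0.85 log units; beyond the scatter) as well, whereas 6-(methanesulfonamido)pyridin-3-yl stayed within the scatter of that substituent. Nothing available explains the change.

Going by these compounds, whether an acetyl or a methyl on this nitrogen tracks the hydrogen or the methylsulfonyl remains open. So does whether a hydroxyl in place of the amine keeps the lower number.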